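This account rests on a few compounds, and the source may have more. Where it says the series, first, only, none or still open, it means among the compounds named here.

Measured compounds:
- compound 1 `Cc1cn(-c2cc(NC(=O)c3ccc(C)c(Nc4nc(-c5cccnc5)cs4)c3)cc(C(F)(F)F)c2)cn1`: 30 nM
- compound 2 `Cc1ncn(-c2cc(NC(=O)c3ccc(C)c(Nc4nc(-c5cccnc5)cs4)c3)cc(C(F)(F)F)c2)n1`: 38 nM
- compound 3 `Cc1cn(-c2cc(NC(=O)c3ccc(C)c(Nc4nc(-c5cccnc5)cs4)c3)cc(C(C)(C)C)c2)cn1`: 11 nM

All three were tested in a functional assay on KU812 cells (Homo sapiens) for antiproliferative activity; on this read-out lower numbers stand for stronger inhibition and higher numbers for weaker inhibition. Among the measured compounds, compound 1 stands second highest of three numbers; compound 2 lies nearest, since the step of a 1.3-fold higher number from compound 1 to compound 2 (0.10 log units; within the scatter) is within the scatter, while compound 3 lies furthest, with the step of a 2.7-fold lower number from compound 1 to compound 3 (0.44 log units; beyond the scatter) reaching beyond it.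

Compound 4 `Cc1cn(-c2cc(NC(=O)c3cccc(Nc4nc(-c5cccnc5)cs4)c3)cc(C(F)(F)F)c2)cn1` has not yet been tested. It differs from compound 1 in one place: hydrogen in place of methyl on an aromatic carbon.

Neither measured step touches this position. The step from compound 1 to compound 2 exchanges one ring for another, and the step from compound 1 to compound 3 exchanges trifluoromethyl for tert-butyl; both sit elsewhere on the shared core. Those steps were small to modest in size, so the scatter of the shared core is at least known, but nothing measured shows what removing this methyl does. The expectation therefore rests on compound 1 alone, with a wide range, and a somewhat higher number is expected as the more likely outcome, in the form of the step of a 3.0-fold higher number from compound 1 to compound 4 (0.48 log units; beyond the scatter). Compound 4 is accordingly estimated at 90 nM, with a range from 25 nM to 400 nM.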

Compound 4, half-maximal inhibitory concentration: 2730 nM
For compound 4 the middle estimate is 30-fold (1.48 log units) below the measured one; measured number above the stated range.
By their numbers in this assay, from the lowest: compound 3; then compounds 1 and 2 (each within the scatter of the next); then compound 4.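

In this assay the methyl on the six-membered aromatic ring of carbon only, ortho to the (4-(pyridin-3-yl)-1,3-thiazol-2-yl)amino group and para to a large group, proves far more important than the earlier changes: its replacement by hydrogen gives a 91-fold higher number from compound 1 to compound 4 (1.96 log units; beyond the scatter), a much larger step than a 1.3-fold higher number from compound 1 to compound 2 (0.10 log units; within the scatter) or a 2.7-fold lower number from compound 1 to compound 3 (0.44 log units; beyond the scatter) at the other places. Thus the loss of 1 heavy atom at this position outweighs both the exchange of one ring for another and the exchange of trifluoromethyl for tert-butyl. Nothing available explains the size of this step.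

The compounds shown carry only methyl or hydrogen at this position, so it remains open whether an ethyl group, a chlorine atom or a methoxy group could stand in for the methyl. Going by these compounds, it also remains open whether hydrogen here would cost as much alongside the tert-butyl group of compound 3.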